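Aryl group on the ring nitrogen: substituent sweep

This account rests on a few compounds, and the source may have more. Where it says the series, first, only, none or still open, it means among the compounds named here.

Measured so far in a functional assay on MV4-11 cells (Homo sapiens) for cytotoxicity, read by colorimetric assay and MTT assay, with a stated time of 3 days, tested at 1 uM; on this read-out higher numbers stand for a weaker effect at the one concentration tested and lower numbers for a stronger effect:
- compound 1, `O=C1COc2ccc(-c3nn(-c4ccc(Cl)cc4)cc3-c3ccccc3)cc2N1`, gives 108%
- compound 2, `O=C1COc2ccc(-c3nn(-c4ccc(F)cc4)cc3-c3ccccc3)cc2N1`, gives 107%
- compound 3, `O=C1COc2ccc(-c3nn(-c4cc(Cl)cc(Cl)c4)cc3-c3ccccc3)cc2N1`, gives 105%

All three numbers sit at the level that means no effect at the one concentration tested. On the numbers alone compound 3 sits at the low end, but the steps of a number 3 percentage points lower from compound 1 to compound 3 (within the scatter) and a number 2 percentage points lower from compound 2 to compound 3 (within the scatter) are both within the scatter, so nothing separates the three compounds. The halogen swap a number 1 percentage points lower from compound 1 to compound 2 (within the scatter) is likewise within the scatter.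

The next compound, compound 4 , is `O=C1COc2ccc(-c3nn(-c4ccccc4)cc3-c3ccccc3)cc2N1`. Relative to compound 3 the change is phenyl in place of 3,5-dichlorophenyl on an aromatic nitrogen.

The two steps that bear on this change are those that already altered the aryl group on the aromatic nitrogen, from compound 1 to compound 3 and from compound 2 to compound 3; each moved the read-out in this assay by only a few points and neither left the scatter. Within the data shown here, removing both chlorines is a change of the same kind, at the same place, and there is no measured step in which any aryl change at this position has moved the number. The expectation for compound 4 is therefore a step of no size beyond the scatter, a number 1 percentage points higher from compound 3 to compound 4 (within the scatter).

Compound 4 is estimated at 106%, with a range from 96% to 116%.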

Compound 4, a percentage reported as activity, at one concentration (the size of the read-out at that concentration, not a potency): 117%
For compound 4 the middle estimate is 11 percentage points below the measured one, and the stated range ends below it.
By their numbers in this assay, from the lowest: compounds 3, 2, 1 and 4 (each within the scatter of the next, the first and the last beyond it).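

In this assay, among these compounds, this is the first aryl change on the aromatic nitrogen to leave the scatter, a number 12 percentage points higher from compound 3 to compound 4 (beyond the scatter), whereas the phenyl group of compound 4 does not separate from either para-free single-halogen comparison as printed: a number 10 percentage points higher from compound 2 to compound 4 (within the scatter) and a number 9 percentage points higher from compound 1 to compound 4 (within the scatter) both stay within it. The position can therefore register a modest difference, but only between the phenyl and 3,5-dichlorophenyl groups, and since all four compounds sit at the no-effect level, the difference does not show any gain in cytotoxicity. Nothing available accounts for this step, and it should not be read as a trend across the halogens.

The compounds shown leave open whether any group on this aryl ring other than a halogen, such as an amine, a carboxylic acid or a methoxy group, can bring the read-out down from the no-effect level. From the compounds shown here alone, it also remains open whether replacing the whole aryl group on the aromatic nitrogen with a longer alkyl chain would produce any effect at all.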